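The compounds below may be only part of what the source reports. "The series", "measured", "known", "first", "only" and "open" are said of these compounds alone.

In a functional assay on the whole organism with Rattus norvegicus as the target (on this read-out lower numbers stand for an effect already at smaller amounts and higher numbers for an effect only at larger amounts of compound), compound 1 `Nc1nc2ccc(OCC(F)(F)F)cc2s1` gives 6.5 mg/kg and compound 2 `C#CCn1c(=N)sc2cc(OC(F)(F)F)ccc21` gives 4 mg/kg and these two numbers lie within the usual scatter of each other. Compound 2 therefore stands level with compound 1 on the data so far. The next structure, compound 3 `CCN(CC)C(=O)Cn1c(=N)sc2cc(OC(F)(F)F)ccc21`, carries diethylcarbamoyl in place of ethynyl on a saturated chain carbon bound to an aromatic nitrogen and keeps the rest of compound 2 unchanged. Among the compounds with values here, no measured pair in this small set differs in only one place, so nothing shows directly what this exchange does. The expected change in this assay is a 1.5-fold higher number from compound 2 to compound 3 (0.18 log units; within the scatter) and this estimated step, towards a higher number, stays within the scatter. In this assay compound 3 is estimated at 6 mg/kg with an expected range from 2 mg/kg to 18 mg/kg on this wide uncertainty.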

Compound 3, dose for half-maximal effect: 9 mg/kg
The estimate for compound 3 lay 1.5-fold (0.18 log units) below the measured number; the range from low to high includes it.
By their numbers in this assay, from the lowest: compounds 2, 1 and 3 (each within the scatter of the next, the first and the last beyond it).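

In this assay, within the data shown here, the exchange gives the first step in this set between two compounds that differ in one place: diethylcarbamoyl in place of ethynyl on a saturated chain carbon bound to an aromatic nitrogen brings a 2.3-fold higher number from compound 2 to compound 3 (0.35 log units; beyond the scatter). The step is modest, so this position carries the larger group, with 7 heavy atoms instead of 2, and compound 3 still gives a dose for half-maximal effect at 9 mg/kg, though at a larger amount than compound 2. Nothing at hand explains the direction of this step.

The compounds shown leave open whether the amide as a whole or only its diethylamino part goes with the higher number. They also leave open where an amine, a carboxylic acid or a longer chain on this carbon would fall in this assay.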